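Shortening the Ether Chain from Compound 2 to Compound 3

The compounds below may be only part of what the source reports. "The series", "measured", "known", "first", "only" and "open" are said of these compounds alone.

Of the compounds shown here, two have so far been measured in a functional assay on NCI-H23 cells (Homo sapiens) for antiproliferative activity, read by sulforhodamine B assay; a higher number here means a weaker inhibitor of growth, a lower number a stronger inhibitor of growth. Compound 1 `CC(C)(C)CCOc1cccc(O)c1C(=O)CCc1ccc(O)cc1` reaches only a limit in this assay, reported as > 30000 nM, so no number is known for it. Compound 2 `CC(C)CCCOc1cccc(O)c1C(=O)/C=C/c1ccc(O)cc1` gives 11400 nM in this assay. Compound 2 thus holds the only number shown, since the other value is a limit, as the limit of > 30000 nM in this assay, at which 1 of the 2 values shown sits, records. Compound 3 `CCCCOc1cccc(O)c1C(=O)/C=C/c1ccc(O)cc1` has not yet been measured. It differs from compound 2 in one place: methyl in place of isopropyl on a saturated chain carbon, three bonds along the chain from an oxygen on an aromatic ring. Within the data shown here, no measured pair shows what such a change does here, so no size of step can be read from the data. The step expected from a 1.3-fold higher number from compound 2 to compound 3 (0.12 log units; within the scatter) is small, staying within the usual scatter or leaning slightly toward weaker growth inhibition. Compound 3 is therefore estimated at 15000 nM in this assay, with a range from 5000 nM to 45000 nM.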

Compound 3, concentration for 50% growth inhibition: > 30000 nM
Compound 3 ended at the assay's limit; the forecaster's own chance of this, stated with the estimate: 30%; middle value at least 2.0-fold (0.30 log units) away from the limit.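

Among these compounds, the methyl in place of isopropyl, on a saturated chain carbon three bonds along the chain from an oxygen on an aromatic ring, gives the first readable step at this position in this assay: an at least 2.6-fold higher number from compound 2 to compound 3 (0.42 log units; beyond the scatter). The outer end of this ether chain therefore matters here, as removing these carbons takes growth inhibition down by more than the usual scatter. The result for compound 3 is a limit, not a number, so the full size of the step stays unknown, and the only number among the compounds shown still belongs to compound 2: the limit of > 30000 nM in this assay, at which 2 of the 3 values shown sit.

On these data alone, whether a longer chain would lower the number from that of compound 2 remains open. So does whether an amine or a carboxylic acid at the chain end could be tolerated.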